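Swapping the Tail Group of an Amide Side Chain

A few compounds are considered here, and "the series" means these few. Any claim that something is new, unique, unknown or untested is made for them only; others in the source may bear on it.

Compound 1 `Cn1ncc(Cl)c1-c1cc(C(=O)N[C@@H]2CN[C@H](CCN3CCCCC3)C[C@H]2c2ccc(Cl)c(Cl)c2)oc1Cl` was tested in an assay for inhibition of RAC-alpha serine/threonine-protein kinase (Homo sapiens), read by HTRF, with a stated time of 1 h (on this read-out lower numbers stand for stronger inhibition and higher numbers for weaker inhibition), where compound 1 gives 5.65 nM. Compound 2 `Cn1ncc(Cl)c1-c1cc(C(=O)N[C@@H]2CN[C@H](CC(=O)NCC(O)CO)C[C@H]2c2ccc(Cl)c(Cl)c2)oc1Cl` differs from it only at the side chain, and in this assay compound 2 gives 3.13 nM. Going by the values given here, the step of a 1.8-fold lower number from compound 1 to compound 2 (0.26 log units; within the scatter) shows that this exchange did not move the read-out beyond the scatter, so compound 2 and compound 1 stand side by side on the two numbers measured so far.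

Compound 3 `Cn1ncc(Cl)c1-c1cc(C(=O)N[C@@H]2CN[C@H](CC(=O)NC3CCC3)C[C@H]2c2ccc(Cl)c(Cl)c2)oc1Cl` is built from compound 2 by the change (cyclobutyl in place of 2,3-dihydroxypropyl on an amide-type nitrogen). Among the compounds with values here, the only step bearing on it, a 1.8-fold lower number from compound 1 to compound 2 (0.26 log units; within the scatter), replaced a group at the same side chain and stayed within the scatter. On that basis the step of a 1.3-fold higher number from compound 2 to compound 3 (0.11 log units; within the scatter) is expected to stay within the scatter as well. For compound 3 in this assay the estimate is 4 nM, with a range from 1.5 nM to 11 nM.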

Compound 3, half-maximal inhibitory concentration: 7.98 nM
Estimate against measurement, compound 3: 2.0-fold (0.30 log units) below, and the stated range covers the measured number.
By their numbers in this assay, from the lowest: compounds 2, 1 and 3 (each within the scatter of the next, the first and the last beyond it).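

Going by these compounds alone, on the amide-type nitrogen, the end of the side chain now shows a measurable, though small, preference: putting cyclobutyl in place of 2,3-dihydroxypropyl in this assay gives a 2.5-fold higher number from compound 2 to compound 3 (0.41 log units; beyond the scatter), the first step in this set to pass beyond the scatter. The larger exchange of the whole tail, by contrast, gives a 1.4-fold higher number from compound 1 to compound 3 (0.15 log units; within the scatter), so compound 3 cannot be told apart from the piperidine-bearing compound 1 even though it is separated from compound 2. No supporting measurement is available to explain why the cyclobutyl step goes in this direction.

The compounds shown leave open which part of the 2,3-dihydroxypropyl group matters, since a chain carrying one hydroxyl, or a plain propyl chain, could separate the ring from the hydroxyl groups. They also leave open how an amine or a carboxylic acid at the end of the chain would read in this assay.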